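This account rests on a few compounds, and the source may have more. Where it says the series, first, only, none or still open, it means among the compounds named here.

Series so far:
- compound 1 `COc1cccc(C2NN=C(c3cc(OC)c(OC)c(OC)c3)C2O)c1`: 7350 nM
- compound 2 `COc1ccc(C2NN=C(c3cc(OC)c(OC)c(OC)c3)C2O)cc1`: 2670 nM
- compound 3 `COc1cc(C2=NNC(c3ccc(Cl)cc3)C2O)cc(OC)c1OC`: not yet measured

In a functional assay on SW-620 cells (Homo sapiens) for inhibition (a lower number here means a stronger inhibitor, a higher number a weaker inhibitor), compound 2 gives the lower of the two numbers, 2670 nM, against compound 1 at 7350 nM.

Compound 3 has chloro in place of methoxy on an aromatic carbon, para to a large group: chloro in place of methoxy on an aromatic carbon. Going by the values given here, the only measured step, a 2.8-fold lower number from compound 1 to compound 2 (0.44 log units; beyond the scatter), is modest and shifts the methoxy rather than replacing it, so it bears on this change only loosely. It shows that this aryl group can move the number, but gives no direction for chloro. No step beyond the scatter is therefore expected in this assay, though one of similar modest size either way remains possible. The estimated change is a 1.1-fold lower number from compound 2 to compound 3 (0.03 log units; within the scatter). For compound 3 the expected value is 2500 nM, with an estimated range of 800 nM to 8000 nM.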

Compound 3, half-maximal inhibitory concentration: 8410 nM
Compound 3: middle estimate off by 3.4-fold (0.53 log units), on the low side; the measured number lies above the stated range.
By their numbers in this assay, from the lowest: compound 2; then compounds 1 and 3 (each within the scatter of the next).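

Replacing the methoxy, rather than only shifting it, gives the aryl position a direction: in this assay, chloro in place of methoxy on the aromatic carbon gives a 3.1-fold higher number from compound 2 to compound 3 (0.50 log units; beyond the scatter). The 4-chlorophenyl of compound 3 and the 3-methoxyphenyl of compound 1 stand within the scatter of each other, with a 1.1-fold higher number from compound 1 to compound 3 (0.06 log units; within the scatter), so among these three aryl groups only the 4-methoxyphenyl of compound 2 stands apart from the others. Nothing available explains the step from methoxy to chloro.

The compounds shown leave open whether the lower number of compound 2 is specific to methoxy or is shared by other groups on that aromatic carbon. An amine, a hydroxy group or a longer chain such as ethoxy at the same place would help separate these two readings.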